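Replacing the sulfur-linked group of compound 2

The source may report more compounds than this note shows. Statements on the series, on what has been measured and on what is new or still open speak of the compounds shown alone.

Among the compounds with values here, in a functional assay on MIA PaCa-2 cells (Homo sapiens) for antiproliferative activity, read by luminescence, with a stated time of 72 h (a higher number here means a weaker inhibitor, a lower number a stronger inhibitor), compound 2 `CN1CC=C(c2c(O)cc(O)c3c(=O)cc(-c4ccc(Sc5nc6ccccc6n5C)cc4)oc23)CC1` gives 361 nM, the lowest of the two numbers so far. Compound 1 `CN1CC=C(c2c(O)cc(O)c3c(=O)cc(-c4ccc(Sc5nc6ccccc6[nH]5)cc4)oc23)CC1` gives 852 nM. Compound 3 `CN1CC=C(c2c(O)cc(O)c3c(=O)cc(-c4ccc(Sc5nc(-c6ccccc6)c[nH]5)cc4)oc23)CC1` has not yet been measured. It carries 4-phenyl-1H-imidazol-2-yl in place of 1-methyl-1H-benzimidazol-2-yl on a sulfur.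

Within the data shown here, one measured step bears on this change, and only in part. Methyl in place of hydrogen on an aromatic nitrogen gave a 2.4-fold lower number from compound 1 to compound 2 (0.37 log units; beyond the scatter), a modest step beyond the scatter. Compound 3 loses that methyl and has hydrogen on an aromatic nitrogen, as compound 1 does, so part of that step may be reversed. Among the measured compounds shown here, the exchange of the ring system itself has no measured counterpart, which leaves both the size and the direction of its contribution open and calls for a wide range. A modest move to a higher number is therefore expected in this assay, with an estimated size of a 2.1-fold higher number from compound 2 to compound 3 (0.32 log units; beyond the scatter). For compound 3 the estimated value is 750 nM, with an expected range of 250 nM to 2200 nM.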

Compound 3, half-maximal inhibitory concentration: 448 nM
The estimate for compound 3 lay 1.7-fold (0.22 log units) above the measured number; measured number inside the range.
By their numbers in this assay, from the lowest: compounds 2, 3 and 1 (each within the scatter of the next, the first and the last beyond it).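

In this assay, the exchange of 1-methyl-1H-benzimidazol-2-yl for 4-phenyl-1H-imidazol-2-yl on the sulfur gives a 1.2-fold higher number from compound 2 to compound 3 (0.09 log units; within the scatter), so this position accepts a different two-ring group without a separable change in the number. The exchange of 1H-benzimidazol-2-yl for the same group gives a 1.9-fold lower number from compound 1 to compound 3 (0.28 log units; within the scatter), which shows that a hydrogen on an aromatic nitrogen can stand in a compound whose number lies within the scatter of compound 2, even though the methyl step in the benzimidazole pair lies beyond it. No measurement at hand gives a reason for these numbers.

Open, as far as these compounds go, is whether a methyl in place of the hydrogen on the aromatic nitrogen of 4-phenyl-1H-imidazol-2-yl would repeat a 2.4-fold lower number from compound 1 to compound 2 (0.37 log units; beyond the scatter), or whether that step belongs to the benzimidazole pair alone. Also open, from the compounds shown here alone, is how this position responds to groups of another kind on the sulfur, such as a carboxylic acid, an amine or a longer alkyl chain.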